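This account rests on a few compounds, and the source may have more. Where it says the series, first, only, none or still open, it means among the compounds named here.

Of the compounds shown here, two sharing one core have been tested in an ADME assay on PANC-1 cells (Homo sapiens) for inhibition, read by MTT assay; a lower number here means a stronger inhibitor of growth, a higher number a weaker inhibitor of growth. Compound 1, `Cc1nc(C)c(-c2nn(-c3ccc(F)cc3)cc2/C=C/C(=O)c2cc(Cl)ccc2O)s1`, gives only a limit, > 250 ug/mL, in this assay. Among the compounds with values here, compound 2, `Cc1ccc(O)c(C(=O)/C=C/c2cn(-c3ccc(F)cc3)nc2-c2sc(C)nc2C)c1`, gives 52.4 ug/mL in this assay, and this is the only actual number among the values shown. Within the data shown here, the single measured change is an at least 4.7-fold lower number from compound 1 to compound 2 (0.67 log units; beyond the scatter). Compound 3, `Cc1nc(C)c(-c2nn(-c3ccc(F)cc3)cc2/C=C/C(=O)c2cc(Cl)cc(Cl)c2O)s1`, has not yet been measured; it differs from compound 2 by 3,5-dichloro-2-hydroxyphenyl in place of 2-hydroxy-5-methylphenyl on a carbonyl carbon. Among the measured compounds shown here, this change reverses the measured step, putting chloro back where methyl stood, and adds a second chloro, for which no measured step exists. Going from compound 2 back toward a chloro-bearing ring points to a higher number, as the step of an at least 4.7-fold lower number from compound 1 to compound 2 (0.67 log units; beyond the scatter) shows when read in the opposite direction, with the limit of > 250 ug/mL in this assay, at which 1 of the 2 values shown sits, marking where compound 1 sat. The step expected here is a 4.8-fold higher number from compound 2 to compound 3 (0.68 log units; beyond the scatter), a return toward weaker inhibition of growth. Compound 3 is therefore estimated at 250 ug/mL, within a range from 80 ug/mL to 500 ug/mL, with a real chance that this assay again reports only a limit.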

Compound 3, concentration for 50% growth inhibition: > 250 ug/mL
Compound 3 was reported as a limit; the forecaster's own chance of this, stated with the estimate: 55%; the middle value sits exactly at the limit.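

Putting 3,5-dichloro-2-hydroxyphenyl in place of 2-hydroxy-5-methylphenyl on the carbonyl carbon gives an at least 4.7-fold higher number from compound 2 to compound 3 (0.67 log units; beyond the scatter) in this assay. A second pair of compounds now links the ring on this carbonyl carbon to the read-out: among the compounds shown, only the methyl-bearing compound 2 gives an actual number, while the two chloro-bearing compounds, compound 1 and compound 3, both stop at the same limit of the assay: the limit of > 250 ug/mL in this assay, at which 2 of the 3 values shown sit.

Both of those values are limits, so the step that adds the second chloro, from compound 1 to compound 3, cannot be read, and the second chloro cannot be said to change anything by itself.

Still open, going by these compounds, is how far the true values of compound 1 and compound 3 lie past that limit, and so whether one chloro and two chloro groups differ at all. Also open is whether an ethyl group, a methoxy group or an amine in the place of the methyl would give a lower number than compound 2 at 52.4 ug/mL, or whether the methyl is the only group shown here that gives a number.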